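A few compounds are considered here, and "the series" means these few. Any claim that something is new, unique, unknown or untested is made for them only; others in the source may bear on it.

Measured so far in an ADME assay on microsomes from liver (Mus musculus) for metabolic stability, using NADPH, with a stated time of 10 min; a lower number here means that less of the compound is left, a higher number that more of the compound is left:
- Compound 1 `CN(C[C@H]1Cc2c(cccc2N2C[C@H]3CNC[C@H]3C2)CN1)[C@H]1CCCc2cccnc21` gives 54.7%
- Compound 2 `CN(C)C1CCN(c2cccc3c2C[C@H](CN(C)[C@H]2CCCc4cccnc42)NC3)CC1` gives 70.2%

Compound 2 holds the higher of these two numbers, so more of it is left at the end of the test. Compound 3 `CN(C[C@H]1Cc2c(cccc2N[C@H]2CC[C@H](N)CC2)CN1)[C@H]1CCCc2cccnc21` has not been measured yet. It differs from compound 2 in one group on the shared core: (4-aminocyclohexyl)amino in place of 4-(dimethylamino)piperidin-1-yl on an aromatic carbon.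

Among the compounds with values here, only one measured step bears on this change: a number 15.5 percentage points higher from compound 1 to compound 2 (beyond the scatter). That modest step also exchanged one group for another on an aromatic carbon, and it ended at the 4-(dimethylamino)piperidin-1-yl group that compound 3 gives up. Within the data shown here, no measured compound carries the (4-aminocyclohexyl)amino group, so its own effect is unknown. Among the measured compounds shown here, with compound 1, the only other compound measured, at 54.7%, a modest fall is expected rather than a rise, though one step is thin support. The expected change is a number 8.2 percentage points lower from compound 2 to compound 3 (within the scatter). The estimate for compound 3 is 62%, with an expected range from 42% to 82%.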

Compound 3, percent of the compound remaining: 100%
Beside the measured number, compound 3's estimate is 38 percentage points below it; the measured number lies above the stated range.
By their numbers in this assay, from the lowest: compound 1; then compound 2; then compound 3.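

In this assay, the group on this aromatic carbon can shift the result much further than the earlier pair suggested: (4-aminocyclohexyl)amino gives a number 29.8 percentage points higher from compound 2 to compound 3 (beyond the scatter), and its step from the other measured group gives a number 45.3 percentage points higher from compound 1 to compound 3 (beyond the scatter). Among these three compounds, the group with a six-membered non-aromatic ring of carbon only stands above both groups whose non-aromatic rings hold a hetero atom, and none of the three goes against this order. The change also brings 2 hydrogen-bond donors where the departing 4-(dimethylamino)piperidin-1-yl group has 0, but nothing available explains why the number rises.

The compounds shown leave open which part of the entering group goes with the higher number: the carbon-only ring, the amine nitrogen joining it to the aromatic carbon, or the amino group on the ring. Going by these compounds, a hydroxyl or a dimethylamino group in place of that amino group on the same cyclohexyl ring would help separate these parts, and the role of the 2 defined stereocentres also remains open.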